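This account rests on a few compounds, and the source may have more. Where it says the series, first, only, none or still open, it means among the compounds named here.

Compound 1, `CC(C)=CCC/C(C)=C/CC1Cc2c(OC(=O)Nc3cccc(F)c3)cc(=O)n(CCCO)c2CC1(C)C`, in a functional assay on PANC-1 cells (Homo sapiens) for inhibition, read by MTT assay, with a stated time of 24 h, tested at 10 uM (on this read-out lower numbers stand for less inhibition and higher numbers for more inhibition at the one concentration tested (going by the name of the read-out)), gives 52.3%.
Compound 2, `CC(C)=CCC/C(C)=C/CC1Cc2c(OC(=O)Nc3ccc(F)c(F)c3)cc(=O)n(CCCO)c2CC1(C)C`, in this assay gives 43.7%.

The two numbers do not separate: the step of a number 8.6 percentage points lower from compound 1 to compound 2 (within the scatter) lies within the scatter, so compound 2 and compound 1 stand together, with compound 2 carrying the smaller figure only nominally. Compound 3, `CC(C)=CCC/C(C)=C/CC1Cc2c(OC(=O)Nc3ccc(Cl)c(Cl)c3)cc(=O)n(CCCO)c2CC1(C)C`, shares the whole core with compound 2 and differs from it in one place: 3,4-dichlorophenyl in place of 3,4-difluorophenyl on an amide-type nitrogen. Among the measured compounds shown here, the single measured step, fluoro in place of hydrogen on an aromatic carbon from compound 1 to compound 2, does not touch an exchange of one halogen for another, so no measured step bears on the move to compound 3; the only guidance is that the one change tried on this ring stayed within the scatter. Compound 3 is therefore expected to stay near compound 2, with the step of a number 2.3 percentage points higher from compound 2 to compound 3 (within the scatter) expected to lie within the scatter. The estimate for compound 3 in this assay is 46%, expected to fall between 26% and 66%.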

Compound 3, a percentage reported as inhibition, at one concentration (the size of the read-out at that concentration, not a potency): 20%
The estimate for compound 3 lay 26 percentage points above the measured number; the whole stated range lies above it.
By their numbers in this assay, from the lowest: compound 3; then compounds 2 and 1 (each within the scatter of the next).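

In this assay, among the compounds shown here, the halogen on the aryl group at the amide-type nitrogen turns out to matter: 3,4-dichlorophenyl in place of 3,4-difluorophenyl gives a number 23.7 percentage points lower from compound 2 to compound 3 (beyond the scatter) and is the first step at this position to pass beyond the scatter. Set against the 3-fluorophenyl group, the same 3,4-dichlorophenyl group gives a number 32.3 percentage points lower from compound 1 to compound 3 (beyond the scatter) and is a larger step, so the chlorinated compound 3 stands apart from both fluorinated compounds, which remain within the scatter of each other. Nothing available explains why the exchange of fluoro for chloro carries this drop in the read-out.

The compounds shown do not tell whether one chloro on the phenyl ring would already lower the number or whether the 3,4-dichlorophenyl pattern as a whole is needed. They also leave open how a bromo, methoxy or trifluoromethyl group, or a plain phenyl, would read at this position, and, since each figure comes from one concentration, how these steps would translate into potency.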